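This account rests on a few compounds, and the source may have more. Where it says the series, first, only, none or still open, it means among the compounds named here.

Three compounds share one core. In a functional assay on HepG2 cells (Homo sapiens) for cytotoxicity, with a stated time of 24 h (on this read-out lower numbers stand for stronger inhibition and higher numbers for weaker inhibition), compound 1 `COc1ccc(C(=O)N/N=C/c2cc(I)cc(I)c2O)cc1` gives 45200 nM, compound 2 `CC(C)(C)c1ccc(C(=O)N/N=C/c2cc(I)cc(I)c2O)cc1` gives 41600 nM, and compound 3 `O=C(N/N=C/c1cc(I)c(O)c(I)c1)c1ccccc1` gives 191000 nM, the highest of the three numbers, standing beyond the scatter from both others. Going by the values given here, the only step measured within this set, a 1.1-fold lower number from compound 1 to compound 2 (0.04 log units; within the scatter), concerns a swap of one group for another on an aromatic carbon and left the number essentially unchanged. Compound 4 `O=C(N/N=C/c1cc(I)c(O)c(I)c1)c1ccc(I)cc1` differs from compound 3 by iodo in place of hydrogen on an aromatic carbon. Because a 1.1-fold lower number from compound 1 to compound 2 (0.04 log units; within the scatter) changed little at a comparable place, the step from compound 3 to compound 4 is expected to be small, a 1.3-fold lower number from compound 3 to compound 4 (0.10 log units; within the scatter). In this assay compound 4 is estimated at 150000 nM, with a range from 60000 nM to 400000 nM.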

Compound 4, half-maximal inhibitory concentration: > 50000 nM
Compound 4 was reported as a limit (the forecaster's own chance of this, stated with the estimate: 20%); the middle value is on the limit's open side.
By their numbers in this assay, from the lowest: compounds 2 and 1 (each within the scatter of the next); then compound 3.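

Going by these compounds alone, compound 4 is reported only as a limit, > 50000 nM, so no step from compound 3 to compound 4 can be read. The compounds shown leave open whether iodo in place of hydrogen on an aromatic carbon changes the number in this assay at all.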